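This account rests on a few compounds, and the source may have more. Where it says the series, first, only, none or still open, it means among the compounds named here.

In a functional assay on K562/A02 cells (Homo sapiens) for antiproliferative activity, read by MTT assay (on this read-out higher numbers stand for weaker inhibition and lower numbers for stronger inhibition), compound 1 `C/C(=N\NC(=S)NCCCCCC(=O)NO)c1ccc(Br)cc1` gives 440 nM and compound 2 `COc1cccc(/C(C)=N/NC(=S)NCCCCCC(=O)NO)c1` gives 1890 nM, so compound 2 holds the higher of the two numbers and is the weaker inhibitor of the pair. Compound 3 `C/C(=N\NC(=S)NCCCCCC(=O)NO)c1cccc(C(F)(F)F)c1` has not yet been measured. It carries trifluoromethyl in place of methoxy on an aromatic carbon, meta to a large group: trifluoromethyl in place of methoxy on an aromatic carbon. For the measured compounds named here, only one measured step bears on this change, a 4.3-fold higher number from compound 1 to compound 2 (0.63 log units; beyond the scatter), a modest step beyond the scatter. It is indirect evidence, as it involves a different group, but it shows that compound 1, which lacks the methoxy group, gives the lower number. A modest move in this assay towards a lower number is therefore expected. The expected step is a 2.1-fold lower number from compound 2 to compound 3 (0.32 log units; beyond the scatter). Compound 3 is estimated at 900 nM, with an expected range from 320 nM to 2500 nM.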

Compound 3, half-maximal inhibitory concentration: 890 nM
Estimate against measurement, compound 3: 1.0-fold (0.00 log units) above, within the range that was stated.
By their numbers in this assay, from the lowest: compound 1; then compound 3; then compound 2.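

In this assay, trifluoromethyl in place of methoxy gives a 2.1-fold lower number from compound 2 to compound 3 (0.33 log units; beyond the scatter). This shows that the group on this aromatic carbon, meta to a large group, moves the number on its own, whereas the earlier step, a 4.3-fold higher number from compound 1 to compound 2 (0.63 log units; beyond the scatter), exchanged the group and its place together. Methoxy brings one hydrogen-bond acceptor and trifluoromethyl none, so the lower number of this pair does not require an acceptor in this group, though nothing measured here explains the change.

As far as these compounds go, it remains open whether bromine on this same carbon would come closer to compound 1 at 440 nM, so the contributions of group and place are still not separated. From the compounds shown here alone, how an amine or a carboxylic acid would behave at this position is also open.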